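This account rests on a few compounds, and the source may have more. Where it says the series, first, only, none or still open, it means among the compounds named here.

In a functional assay on HeLa cells (Homo sapiens) for cytotoxicity, read by MTT assay, with a stated time of 24 h (on this read-out higher numbers stand for weaker inhibition and lower numbers for stronger inhibition), the measured compounds stand as follows:

Compound 1, `CCNC(=O)Cn1nc(N)c2c(C(F)(F)F)cc(-c3ccccc3)nc21`: 20200 nM
Compound 2, `NNC(=O)Cn1nc(N)c2c(C(F)(F)F)cc(-c3ccccc3)nc21`: 48400 nM
Compound 3, `Nc1nn(CC(=O)NC2CC2)c2nc(-c3ccccc3)cc(C(F)(F)F)c12`: "not active" (no number reported)

Compound 2 has the highest number of the two that were reported as numbers. Its nearest neighbour is compound 1, and the step of a 2.4-fold higher number from compound 1 to compound 2 (0.38 log units; beyond the scatter) is a modest rise that lies beyond the scatter. Compound 3 carries a cyclopropyl on the amide-type nitrogen and was reported as not active, so it offers no number to set beside the others.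

Compound 4, `Nc1nn(CC(=O)NC2CCCCC2)c2nc(-c3ccccc3)cc(C(F)(F)F)c12`, is not yet measured in this assay. It differs from compound 2 in one place: cyclohexyl in place of amino on an amide-type nitrogen.

Going by the values given here, only one measured step touches the amide-type nitrogen, the one from compound 1 to compound 2, and it runs from ethyl to amino, not from amino to a ring. Compound 3 shows that a carbon ring on this nitrogen can give no activity at all. On that basis the step of a 1.6-fold lower number from compound 2 to compound 4 (0.21 log units; within the scatter) is expected to stay within the scatter, though a reported limit instead of a number cannot be ruled out. Compound 4 is therefore estimated at 30000 nM, with a range from 8000 nM to 120000 nM.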

Compound 4, half-maximal inhibitory concentration: 3900 nM
For compound 4 the middle estimate is 7.7-fold (0.89 log units) above the measured one; measured number below the stated range.
By their numbers in this assay, from the lowest: compound 4; then compound 1; then compound 2.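

In this assay, the amide-type nitrogen proves able to carry a six-membered carbon ring with a clear gain: the step is large for a 12-fold lower number from compound 2 to compound 4 (1.09 log units; beyond the scatter) and modest for a 5.2-fold lower number from compound 1 to compound 4 (0.71 log units; beyond the scatter), both beyond the scatter, so cyclohexyl gives the lowest number of the three compounds with numbers. A carbon ring on this nitrogen therefore does not in itself cost all activity, yet compound 3, with cyclopropyl, stands as "not active" (no number reported), and the steps to it cannot be read, so the order of cyclohexyl, ethyl and amino cannot be extended to that ring. Nothing available here accounts for the effect of cyclohexyl on this read-out.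

The compounds shown leave open whether the number keeps falling with other groups on this nitrogen, such as cyclopentyl, cycloheptyl, phenyl, benzyl or a longer chain like n-hexyl, or whether a ring holding a nitrogen or an oxygen atom, such as piperidin-4-yl or tetrahydropyran-4-yl, would serve as well. They also leave open whether cyclohexyl would give a similar step if the phenyl or the trifluoromethyl on the shared core were replaced.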